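The source may hold more compounds than are shown below. What is called first, only, known or untested is meant among the compounds shown, and "the series" means these compounds.

Measured in a physicochemical assay for solubility; a higher number here means a more soluble compound, a lower number a less soluble compound:
- compound 1 `CNC(=O)c1cc(C(=O)N[C@H]2[C@@H]3C[C@@H](O)C[C@@H]32)cc2c1OC[C@H]2c1ccccc1`: >= 124 ug/mL (a limit)
- compound 2 `CCC(=O)N1C[C@@H]2[C@H](C1)[C@H]2NC(=O)c1cc(C(=O)NC)c2c(c1)[C@H](c1ccccc1)CO2`: >= 163 ug/mL (a limit)

For compound 2 the read-out is a limit and not a number: >= 163 ug/mL. It therefore gives a floor to start from and no exact position. Among the compounds with values here, the only measured step is a step that the two limits leave unreadable from compound 1 to compound 2. That step has no readable size, so no magnitude can be carried forward from it.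

Compound 3 `CNC(=O)c1cc(C(=O)Nc2cnn(C)c2)cc2c1OC[C@H]2c1ccccc1` is not yet measured. It carries 1-methyl-1H-pyrazol-4-yl on the amide-type nitrogen: a group of 6 heavy atoms (4 carbon, 2 nitrogen; one five-membered aromatic ring with 2 hetero atoms) in place of a group of 10 heavy atoms (8 carbon, 1 nitrogen, 1 oxygen; one three-membered non-aromatic ring of carbon only, one five-membered non-aromatic ring with 1 hetero atom), on an amide-type nitrogen. Within the data shown here, both measured compounds have non-aromatic ring groups at this place, so no measured step covers a five-membered aromatic ring there. The expectation is therefore a judgement on the structural change alone, and it is held loosely.

The expected change is an at least 2.7-fold lower number from compound 2 to compound 3 (0.43 log units; beyond the scatter), a fall in this assay whose size stays uncertain while the starting point is a limit. Compound 3 is estimated at 60 ug/mL, with an expected range from 15 ug/mL to 170 ug/mL.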

Compound 3, solubility: >= 189 ug/mL
Compound 3 was reported as a limit (the forecaster's own chance of this, stated with the estimate: 30%); middle value at least 3.1-fold (0.49 log units) away from the limit.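

In this assay, within the data shown here, compound 1, compound 2 and compound 3 are all reported as limits, and no step among them can be read. The compounds shown leave open the true solubility of each one, and whether 1-methyl-1H-pyrazol-4-yl on the amide-type nitrogen changes the read-out at all relative to the groups it replaces.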